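Carbonyl substituent series on the shared core

A few compounds are considered here, and "the series" means these few. Any claim that something is new, unique, unknown or untested is made for them only; others in the source may bear on it.

Measured compounds:
compound 1 `Cc1nc(S(C)(=O)=O)ccc1Oc1ncnc(OC2CCN(C(=O)OC(C)(C)C#N)CC2)c1F` — 1320 nM
compound 2 `Cc1nc(S(C)(=O)=O)ccc1Oc1ncnc(OC2CCN(C(=O)OC(C)(C)CF)CC2)c1F` — 138 nM
compound 3 `Cc1nc(S(C)(=O)=O)ccc1Oc1ncnc(OC2CCN(C(=O)SC(C)(C)C)CC2)c1F` — 30.7 nM

All three share one core and differ only in the group attached to the carbonyl carbon. In a functional assay on isolated protein for inhibition of Glucose-dependent insulinotropic receptor (Rattus norvegicus), read by HTRF and cAMP accumulation (a higher number here means that more compound is needed for the effect, a lower number that less compound is needed), compound 3 gives 30.7 nM, the lowest number of the three: a 43-fold lower number from compound 1 to compound 3 (1.63 log units; beyond the scatter) and a 4.5-fold lower number from compound 2 to compound 3 (0.65 log units; beyond the scatter), so its margin over both others lies beyond the scatter. The remaining step, a 9.6-fold lower number from compound 1 to compound 2 (0.98 log units; beyond the scatter), is also beyond the scatter.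

Compound 4 `Cc1nc(S(C)(=O)=O)ccc1Oc1ncnc(OC2CCN(C(=O)c3noc(C(C)C)n3)CC2)c1F` is not yet measured. Its change from compound 3: 5-isopropyl-1,2,4-oxadiazol-3-yl in place of (tert-butyl)sulfanyl on a carbonyl carbon. Every measured step sits at this same carbonyl carbon. None of them exchanges a chain for a ring, so their size is only a rough guide. The spread among compounds 1, 2 and 3 shows this position tolerates large swings in this assay. With no aromatic substituent at this position yet measured, the expectation for compound 4 is a modest rise in number, so that a 1.8-fold higher number from compound 3 to compound 4 (0.25 log units; within the scatter) is expected to be small and close to the scatter. Compound 4 is therefore estimated at 55 nM, with a range from 15 nM to 220 nM.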

Compound 4, half-maximal effective concentration: 176 nM
For compound 4 the middle estimate is 3.2-fold (0.51 log units) below the measured one; low and high end bracket the measured number.
By their numbers in this assay, from the lowest: compound 3; then compounds 2 and 4 (each within the scatter of the next); then compound 1.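

Notes on the carbonyl carbon, in this assay: replacing (tert-butyl)sulfanyl with the 5-isopropyl-1,2,4-oxadiazol-3-yl group, the first ring shown at this position, gives a 5.7-fold higher number from compound 3 to compound 4 (0.76 log units; beyond the scatter), so this aromatic ring brings no gain over the best chain group here. Set against the 1-cyano-1-methylethoxy group, the same ring gives a 7.5-fold lower number from compound 1 to compound 4 (0.88 log units; beyond the scatter), while the step from the fluorinated carbamate chain, a 1.3-fold higher number from compound 2 to compound 4 (0.11 log units; within the scatter), does not separate the two. The position therefore accepts a five-membered aromatic ring with 3 hetero atoms, attached through ring carbon, and its number falls inside the range already spanned by the three chain groups, so a chain is not required at this carbonyl carbon.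

Open, as far as these compounds go, is which part of the new group sets the number, since the ring and its isopropyl arrive together, and a plain phenyl ring, a 5-tert-butyl-1,2,4-oxadiazol-3-yl group or a tert-butylamino group on the carbonyl carbon would help to separate those contributions. No supporting data are available to account for any of these steps.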